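Trimming a methyl from a thioether side chain

The compounds below may be only part of what the source reports. "The series", "measured", "known", "first", "only" and "open" are said of these compounds alone.

Compound 1, `Cn1ncc2c(=O)n(-c3ccccc3)c(COc3cccc(F)c3)nc21`, in an assay on isolated protein for inhibition of Retinaldehyde dehydrogenase 3 (Homo sapiens) (on this read-out higher numbers stand for weaker inhibition and lower numbers for stronger inhibition), gives 780 nM.
Compound 2, `Cn1ncc2c(=O)n(-c3ccccc3)c(SC(C)(C)c3ccccc3)nc21`, in this assay gives 1390 nM.
Compound 3, `Cn1ncc2c(=O)n(-c3ccccc3)c(SCc3cccc(F)c3)cc21`, in this assay gives 140 nM.

Among these three numbers, compound 2 has the highest. Its nearest neighbour is compound 1, whose number is lower by an amount that stays within the usual scatter, so the two cannot be told apart on this measurement. Compound 3 lies furthest away, with a number lower by an amount well beyond the scatter.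

Compound 4, `C[C@@H](Sc1nc2c(cnn2C)c(=O)n1-c1ccccc1)c1ccccc1`, has not yet been measured. It differs from compound 2 in one place: 1-phenylethyl in place of 1-methyl-1-phenylethyl on a sulfur. Among the compounds with values here, no pair of already measured compounds differs in exactly this way, so there is no measured step to lean on. A small step is expected in this assay, toward a lower number, but not clearly beyond the scatter. The estimated step is a 2.0-fold lower number from compound 2 to compound 4 (0.30 log units; within the scatter). Compound 4 is therefore estimated at 700 nM, with a range from 250 nM to 2000 nM.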

Compound 4, half-maximal inhibitory concentration: 34 nM
Estimate against measurement, compound 4: 21-fold (1.31 log units) above, and the stated range ends above it.
By their numbers in this assay, from the lowest: compound 4; then compound 3; then compounds 1 and 2 (each within the scatter of the next).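

In this assay, replacing 1-methyl-1-phenylethyl with 1-phenylethyl on a sulfur gives a large change (a 41-fold lower number from compound 2 to compound 4 (1.61 log units; beyond the scatter)), so this position responds strongly to a small edit. The earlier compounds shown here could not show this, as no two of them differed in only one place. The two groups share the same aromatic ring and have no hydrogen-bond donors or acceptors, yet they differ by one carbon and by the defined stereocentre in 1-phenylethyl, and nothing measured here explains the size of the step.

Still open, going by these compounds, is how much of the step belongs to the lost methyl and how much to the stereocentre, which the opposite stereoisomer of compound 4 would help to separate. Also open, on these data alone, is how this position would respond to a plain benzyl group or to an ethyl in place of the remaining methyl.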